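A few compounds are considered here, and "the series" means these few. Any claim that something is new, unique, unknown or untested is made for them only; others in the source may bear on it.

Three compounds have been measured in an ADME assay on HEK293 cells (Homo sapiens) for cytotoxicity, read by luminescence, with a stated time of 72 h (a higher number here means that more compound is needed for the effect, a lower number that less compound is needed), and each result is a limit of the assay, not a number:

Compound 1 `CCOC(=O)c1c(-c2ccccc2)[nH]c2cc(OC)ccc2c1=O`: > 22000 nM
Compound 2 `CCOC(=O)c1c(-c2cccc(OCC)c2)[nH]c2cc(OC)ccc2c1=O`: > 22000 nM
Compound 3 `CCOC(=O)c1c(-c2cccc(F)c2)[nH]c2cc(OC)ccc2c1=O`: > 22000 nM

Compound 3 therefore has no numerical rank in the series. Like the other two compounds, it sits at the limit of > 22000 nM in this assay, at which 3 of the 3 values shown sit.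

The next compound is compound 4 `CCOC(=O)c1c(-c2cccc(F)c2)[nH]c2cc(OC)c(F)cc2c1=O`, which keeps everything in compound 3 except for one change: fluoro in place of hydrogen on an aromatic carbon. The new fluoro group sits ortho to a methoxy group.

The closest measured precedent is the same kind of exchange elsewhere in the molecule, a step that the two limits leave unreadable from compound 1 to compound 3. The other two measured changes are a step that the two limits leave unreadable from compound 1 to compound 2 and a step that the two limits leave unreadable from compound 2 to compound 3. None of these steps has a readable size, so the data show no shift in this assay in either direction, and they cannot exclude one that stays hidden behind the limit.

The expected outcome is no change beyond the scatter, and the estimated step is a number no higher from compound 3 to compound 4 (the limit leaves the size open). The most likely report is another limit. For compound 4 the estimate is 22000 nM, with an expected range from 12000 nM to 40000 nM.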

Compound 4, half-maximal effective concentration: > 22000 nM
Compound 4: a limit, no number (the forecaster's own chance of this, stated with the estimate: 85%); the middle value lies on the limit itself.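

Within the data shown here, the result for compound 4 is a limit of the assay and not a number, as is the result for compound 3, so no step between compound 3 and compound 4 can be read. The series stays at a single limit: the limit of > 22000 nM in this assay, at which 4 of the 4 values shown sit. The compounds shown leave open where any of the four has its half-maximal effective concentration, and whether any fluoro or ethoxy exchange shifts it.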